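Swapping Chloro for Butoxy on a Level Ester

The source may report more compounds than this note shows. Statements on the series, on what has been measured and on what is new or still open speak of the compounds shown alone.

Compound 3 `CCOC(=O)c1cnc(-c2ccccc2Cl)[nH]c1=O` gives 5 mg/kg in a functional assay on the whole organism (strain Sprague-Dawley) for inhibition, with Rattus norvegicus as the target, with a stated time of 10 min; on this read-out lower numbers stand for an effect already at smaller amounts and higher numbers for an effect only at larger amounts of compound. It stands level with compound 1 `O=C(O)c1cnc(-c2ccccc2Cl)[nH]c1=O`, which gives 5 mg/kg. Going by the values given here, the only measured step here is no change at the digits printed from compound 1 to compound 3 (within the scatter), with ethyl in place of hydrogen on an oxygen. In this pair, turning the free acid into its ethyl ester left the dose unchanged at the digits shown.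

Compound 4 `CCCCOc1ccccc1-c1ncc(C(=O)OCC)c(=O)[nH]1` is changed elsewhere in the molecule, with butoxy in place of chloro on an aromatic carbon, ortho to a large group: butoxy in place of chloro on an aromatic carbon. Among the compounds with values here, no measured step tests this swap, so the step from compound 1 is only a weak guide to its size. That step does show that one change to the shared core can leave this assay unmoved.

A third compound sets a caution. Compound 2 `CCOc1ccc(S(=O)(=O)N(C)C)cc1-c1ncc(C(=O)O)c(=O)[nH]1` gives > 50 mg/kg, which is a limit of the assay and not a number. The expected range is kept wide towards larger doses because of the limit of > 50 mg/kg in this assay, at which 1 of the 3 values shown sits, which compound 2 reaches.

The expected step is a 1.4-fold higher number from compound 3 to compound 4 (0.15 log units; within the scatter), so no clear move beyond the scatter is anticipated. Compound 4 is estimated at 7 mg/kg, with an expected range from 1.5 mg/kg to 35 mg/kg.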

Compound 4, dose for 50% inhibition: 0.5 mg/kg
The estimate for compound 4 lay 14-fold (1.15 log units) above the measured number, and the stated range ends above it.
By their numbers in this assay, from the lowest: compound 4; then compounds 1 and 3 (each within the scatter of the next). At a limit, above all of these: compound 2.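

Going by these compounds alone, the one earlier measured step, which turned the free acid into its ethyl ester, left this assay unmoved, so a change to these compounds had not yet been seen to shift the dose beyond the scatter. This swap does, with a 10-fold lower number from compound 3 to compound 4 (1.00 log units; beyond the scatter), which means that the same effect is reached with a much smaller dose. The place on the aromatic carbon, ortho to a large group, is therefore sensitive to what sits there, at least for this pair, but no measurement shown explains why butoxy in place of chloro has this effect.

The compounds shown leave open whether this drop belongs to butoxy in particular, and a shorter methoxy group, a longer hexyloxy chain or an amine at the same place would help to separate the length of the chain from the presence of its oxygen. They also leave open whether the free carboxylic acid carrying butoxy would stay level with its ethyl ester, as the pair of compound 1 and compound 3 does when chloro is present.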